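The source may report more compounds than this note shows. Statements on the series, on what has been measured and on what is new or still open speak of the compounds shown alone.

Measured in a functional assay on A-431 cells (Homo sapiens) for cytotoxicity, read by MTT assay, with a stated time of 72 h, tested at 3 uM (a lower number here means less inhibition of growth, a higher number more inhibition of growth at the concentration tested), so far: compound 1 `Cc1ccnc(/C(N)=N/NC(=S)N2CCSCC2)c1` gives 34.7%; compound 2 `N/C(=N\NC(=S)N1CCSCC1)c1ccccn1` gives 37.2%; compound 3 `N/C(=N\NC(=S)N1CCN(c2ccccn2)CC1)c1ccccn1` gives 45.8%.

Compound 1 holds the lowest of the three numbers in this assay, though compound 2 sits within the scatter of it, as the step of a number 2.5 percentage points higher from compound 1 to compound 2 (within the scatter) for hydrogen in place of methyl on an aromatic carbon shows. Compound 3 lies beyond the scatter above compound 1.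

Compound 4 `Cc1ccnc(/C(N)=N/NC(=S)N2CCCC2)c1` differs from compound 1 by pyrrolidin-1-yl in place of thiomorpholin-4-yl on a thiocarbonyl carbon. Among the compounds with values here, no measured step changes the group on the thiocarbonyl carbon, so nothing in the set bears directly on this change; the one measured step concerns a different place and stayed within the scatter. Compound 3 carries a different ring on that carbon than compound 1 does, but its other parts differ as well, so it is not a one-place comparison. The account therefore expects for compound 4 no step beyond the scatter in this assay, an estimated a number 0.3 percentage points higher from compound 1 to compound 4 (within the scatter). Compound 4 is estimated at 35%, between 22% and 48%.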

Compound 4, percent growth inhibition at one concentration: 63%
Beside the measured number, compound 4's estimate is 28 percentage points below it, outside the stated range (above it).
By their numbers in this assay, from the lowest: compounds 1, 2 and 3 (each within the scatter of the next, the first and the last beyond it); then compound 4.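

Within the data shown here, the group on the thiocarbonyl carbon proves to be a place where a single change moves the number in this assay: pyrrolidin-1-yl in place of thiomorpholin-4-yl gives a number 28.3 percentage points higher from compound 1 to compound 4 (beyond the scatter), whereas the only earlier one-place step, a number 2.5 percentage points higher from compound 1 to compound 2 (within the scatter), concerned an aromatic carbon. The exchange alters two things at once, going from a six-membered ring with 2 hetero atoms to a five-membered ring with 1 hetero atom, so this one step cannot separate ring size from the loss of sulfur. Nothing available accounts for the step.

The compounds shown leave open whether piperidin-1-yl, a six-membered ring without sulfur, or morpholin-4-yl, with oxygen in place of sulfur, would follow pyrrolidin-1-yl or thiomorpholin-4-yl. Also open, going by these compounds, is whether an open-chain dimethylamino group on that carbon would give a similar number, and whether pyrrolidin-1-yl gives the same step on the core of compound 2.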